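From Compound 3 to Compound 4: An Expected Minimum Effective Dose

A few compounds are considered here, and "the series" means these few. Any claim that something is new, unique, unknown or untested is made for them only; others in the source may bear on it.

Compound 1 `N#CN/C(=N\C1CCCCC1)Nc1cccnc1` gives 20 mg/kg in a functional assay on the whole organism (blood, strain Wistar-Okamoto) with Rattus norvegicus as the target, with a stated time of 5 days; a lower number here means that less compound is needed, a higher number that more compound is needed for the effect.
Compound 2 `CC(C)(C)C/N=C(\NC#N)Nc1ccncc1` gives 5 mg/kg in this assay.
Compound 3 `N#CN/C(=N\C1CCCCC1)Nc1ccncc1` gives 20 mg/kg in this assay.

Compound 3 stands level with compound 1, and together they give the highest of the three numbers; the step of no change at the digits printed from compound 1 to compound 3 (within the scatter) lies within the scatter. Compound 2 is furthest away, the step of a 4.0-fold higher number from compound 2 to compound 3 (0.60 log units; beyond the scatter) running toward the higher number. Compound 4 `N#CN/C(=N\C1CCCCC1)Nc1ccccn1` differs from compound 3 in one place: pyridin-2-yl in place of pyridin-4-yl on an amine nitrogen. The step of no change at the digits printed from compound 1 to compound 3 (within the scatter) is the one that bears on this change: it too exchanges one pyridinyl group for another on the same amine nitrogen, and the number did not move. The step of a 4.0-fold higher number from compound 2 to compound 3 (0.60 log units; beyond the scatter) alters the group on the double-bonded nitrogen, which compound 4 keeps, so it does not bear on the change. For the measured compounds named here, no measured compound carries pyridin-2-yl, so the expectation rests on a single step. Compound 4 is therefore expected to show no step beyond the scatter in this assay, namely no change at the digits printed from compound 3 to compound 4 (within the scatter). The estimate for compound 4 is 20 mg/kg, within 10 mg/kg to 50 mg/kg.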

Compound 4, minimum effective dose: > 35 mg/kg
Compound 4 was reported as a limit; the forecaster's own chance of this, stated with the estimate: 10%; at least 1.7-fold (0.24 log units) between middle value and limit.
By their numbers in this assay, from the lowest: compound 2; then compounds 1 and 3 (each within the scatter of the next). At a limit, above all of these: compound 4.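

In this assay compound 4 is reported only as a limit, which is not a number: the limit of > 35 mg/kg in this assay, at which 1 of the 4 values shown sits.

For the compounds shown here, until now, moving between pyridinyl groups on this amine nitrogen had left the dose unchanged at the digits printed, but pyridin-2-yl is the one group of the three that gives no measured dose. The result reads as an at least 1.7-fold higher number from compound 3 to compound 4 (0.24 log units; that floor lies within the scatter) and as an at least 1.7-fold higher number from compound 1 to compound 4 (0.24 log units; that floor lies within the scatter). Both floors lie within the scatter, so the change may be small or large, and the limit does not show that this pyridinyl group truly differs from the other two.

From the compounds shown here alone, how far the dose of compound 4 really lies from the others stays open. So does the effect of pyridin-2-yl alongside neopentyl on the double-bonded nitrogen, and of a phenyl group on the amine nitrogen.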